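This account rests on a few compounds, and the source may have more. Where it says the series, first, only, none or still open, it means among the compounds named here.

Measured compounds:
- compound 1, `CNC(=O)c1ccc(-c2cnc(NCc3c(F)ccc4c3CCO4)c3cn[nH]c(=O)c23)c(C)n1`, in a physicochemical assay for solubility, read by LC-MS, in phosphate buffer, with a stated time of 24 h, at pH 7.4; a higher number here means a more soluble compound, a lower number a less soluble compound: 19000 nM
- compound 2, `CN(c1ccccc1)c1cnc(NCc2c(F)ccc3c2CCO3)n2cnnc12`, in this assay: a limit only, < 2000 nM

In this assay compound 1 gives 19000 nM, a measured number. Compound 2 stands differently: in this assay compound 2 returns only a limit, < 2000 nM, so no number is known for it. Its position is the limit of < 2000 nM in this assay, at which 1 of the 2 values shown sits. Among the compounds with values here, compounds 1 and 2 differ in more than one place, so no single step between them is computed; their two values show only that compound 1 reads inside the measured range while compound 2 does not.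

Compound 3, `CN(c1ccn(C)n1)c1cnc(NCc2c(F)ccc3c2CCO3)n2cnnc12`, is not yet measured. Relative to compound 2 the change is 1-methyl-1H-pyrazol-3-yl in place of phenyl on a nitrogen on an aromatic ring, a swap of one six-membered aromatic ring of carbon only for one five-membered aromatic ring with 2 hetero atoms, carrying 2 hydrogen-bond acceptors where there were none.

Within the data shown here, no measured step of this kind exists in the set, so the expectation rests on the limit for compound 2 alone. A modest rise is expected, an at least 2.0-fold higher number from compound 2 to compound 3 (0.30 log units; that floor lies within the scatter), though a return of another limit remains a real possibility. Compound 3 is estimated at 4000 nM, within a range from 1500 nM to 12000 nM.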

Compound 3, solubility: 130000 nM
The estimate for compound 3 lay 33-fold (1.51 log units) below the measured number; the whole stated range lies below it.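

In this assay, the place on a nitrogen on an aromatic ring, whose other neighbours are an aromatic carbon and a saturated chain carbon, proves open to change: 1-methyl-1H-pyrazol-3-yl in place of phenyl gives an at least 65-fold higher number from compound 2 to compound 3 (1.81 log units; beyond the scatter). Within the data shown here, this is the first single-place step, and with it the read-out moves from a limit to a measured number on the same core. The true size of the step remains unknown, because the value for compound 2 is a limit and not a number, so the step gives only a floor: the limit of < 2000 nM in this assay, at which 1 of the 3 values shown sits.

The step changes ring size, hetero atoms and hydrogen-bond acceptors together, and the compounds shown do not separate these features from one another. Going by these compounds, how a pyridyl group, or a pyrazole without the methyl group, would read on the same nitrogen in this assay stays open, as does whether the step carries over to the core of compound 1.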